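Methoxy in place of chloro on the shared core

The compounds below may be only part of what the source reports. "The series", "measured", "known", "first", "only" and "open" are said of these compounds alone.

In a functional assay on HCT-8 cells (Homo sapiens) for cytotoxicity (a higher number here means that more compound is needed for the effect, a lower number that less compound is needed), compound 1 `Oc1ccc2nc(-c3ccccc3)cc(O)c2c1` gives 7.75 ug/mL and compound 2 `Oc1cc(-c2ccccc2)nc2ccc(Cl)cc12` gives 0.7 ug/mL. Among the measured compounds shown here, compound 2 therefore holds the lower of the two numbers so far, with compound 1 as its only neighbour. The next change leads to compound 3 `COc1ccc2nc(-c3ccccc3)cc(O)c2c1`, with methoxy in place of chloro on an aromatic carbon. For the measured compounds named here, the one measured step bearing on this is an 11-fold lower number from compound 1 to compound 2 (1.04 log units; beyond the scatter), a large step beyond the scatter, for chloro in place of hydroxy on an aromatic carbon. Going by the values given here, it shows what was gained when chloro entered, but the data hold no measured methoxy compound, so it guides the new step only indirectly. In this assay, removing chloro is expected to give back much of that gain, judging by compound 1 at 7.75 ug/mL. A higher number is therefore expected, with an estimated 5.0-fold higher number from compound 2 to compound 3 (0.70 log units; beyond the scatter). The expected value for compound 3 is 3.5 ug/mL, with an estimated range of 1 ug/mL to 12 ug/mL.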

Compound 3, half-maximal effective concentration: 1 ug/mL
Compound 3: the middle estimate sits 3.5-fold (0.54 log units) above what was measured; low and high end bracket the measured number.
By their numbers in this assay, from the lowest: compounds 2 and 3 (each within the scatter of the next); then compound 1.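

In this assay, methoxy and chloro on this aromatic carbon cannot be told apart, with a 1.4-fold higher number from compound 2 to compound 3 (0.15 log units; within the scatter). The free hydroxy of compound 1 now stands alone among the three groups, as methyl in place of hydrogen on that oxygen gives a 7.8-fold lower number from compound 1 to compound 3 (0.89 log units; beyond the scatter), a step beyond the scatter in the same direction as an 11-fold lower number from compound 1 to compound 2 (1.04 log units; beyond the scatter); the lower number is therefore not tied to chloro, and in these three compounds it goes with either of two different groups replacing the hydroxy. Nothing at hand bears on what lies behind this result.

On these data alone, three groups at a single position give only a narrow view, so it remains open whether an unsubstituted carbon, fluoro, an amine or a longer chain such as ethoxy would keep the number of compound 2 and compound 3 or return towards that of compound 1. As far as these compounds go, the rest of the shared core is the same in all three compounds, so the effect of a change elsewhere, and whether this position behaves the same way with such a change in place, also remain open.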